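The compounds below may be only part of what the source reports. "The series", "measured", "known", "first", "only" and "open" are said of these compounds alone.

Working notes on the series, read in an ADME assay for permeability, using PAMPA, at pH 7.4; a higher number here means that the compound crosses the layer faster, a lower number that the compound crosses the layer more slowly. Among the compounds with values here, compound 1 `C[C@@H]1CN(c2cccc3c2C[C@H](CN(C)[C@H]2CCCc4cccnc42)NC3)C[C@H](C)N1` gives 39 nm/s, and compound 2 `CN1CCN(c2cccc3c2C[C@H](CN(C)[C@H]2CCCc4cccnc42)NC3)CC1` gives 996 nm/s, the higher of the two numbers so far. Compound 3 `C[C@@H]1CN(c2cccc3c2C[C@H](CN(C)[C@H]2CCCc4cccnc42)NC3)C[C@H](C)N1C` is still unmeasured. Against compound 2, it has 3,4,5-trimethylpiperazin-1-yl in place of 4-methylpiperazin-1-yl on an aromatic carbon.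

Within the data shown here, only one measured step bears on this change: a 26-fold higher number from compound 1 to compound 2 (1.41 log units; beyond the scatter). It is large and beyond the scatter, but it replaces 3,5-dimethylpiperazin-1-yl with 4-methylpiperazin-1-yl, so two substitution patterns change at once. Compound 3 carries both patterns, and the data do not separate them. A fall of that size is not expected, since compound 2 with the same 4-methyl pattern stands at 996 nm/s. The expected step is a 1.5-fold lower number from compound 2 to compound 3 (0.19 log units; within the scatter), a slight downward move that probably stays within the scatter. The estimate for compound 3 is 650 nm/s, with an expected range from 200 nm/s to 1500 nm/s.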

Compound 3, apparent permeability: 142 nm/s
Beside the measured number, compound 3's estimate is 4.6-fold (0.66 log units) above it; measured number outside the range, below it.
By their numbers in this assay, from the lowest: compound 1; then compound 3; then compound 2.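

With the methyl on the ring amine nitrogen held constant, the extra methyl groups of 3,4,5-trimethylpiperazin-1-yl give a 7.0-fold lower number from compound 2 to compound 3 (0.85 log units; beyond the scatter) in this assay, so this change on the aromatic carbon alone moves the number beyond the scatter. With those extra methyl groups held constant, methyl in place of hydrogen on the ring amine nitrogen gives a 3.6-fold higher number from compound 1 to compound 3 (0.56 log units; beyond the scatter), so the two changes combined in a 26-fold higher number from compound 1 to compound 2 (1.41 log units; beyond the scatter) can now be read separately, and each moves the number beyond the scatter. No measurement bears on why either step occurs.

The compounds shown leave open whether one methyl on a ring carbon would give part of the fall seen with 3,4,5-trimethylpiperazin-1-yl, and whether the other stereochemical arrangement of those two defined stereocentres would give the same number. They also leave open whether the rise from the methyl on the ring amine nitrogen would carry over to a longer chain there, such as ethyl, or whether morpholin-4-yl on the same aromatic carbon would fit these steps at all.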